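This account rests on a few compounds, and the source may have more. Where it says the series, first, only, none or still open, it means among the compounds named here.

Compound 2 `O=c1cc(-c2ccccc2)oc2c(OCCNCCO)c(O)cc(O)c12` carries a 2-((2-hydroxyethyl)amino)ethoxy chain on the shared core; in a functional assay on A549 cells (Homo sapiens) for cytotoxicity, read by MTT assay, with a stated time of 48 h (a higher number here means a weaker inhibitor, a lower number a stronger inhibitor), compound 2 gives "not determined" (no result reported), so no number places it. Among the compounds with values here, the one value shown is a limit of the assay rather than a number: compound 1 `CN1CCN(CCCOc2c(O)cc(O)c3c(=O)cc(-c4ccccc4)oc23)CC1` gives > 100000 nM in this assay. Compound 3 `CN(C)CCCOc1c(O)cc(O)c2c(=O)cc(-c3ccccc3)oc12` arises from compound 2 by one change, ((dimethylamino)methyl in place of (2-hydroxyethyl)amino on a saturated chain carbon, two bonds along the chain from an oxygen on an aromatic ring). Since compound 1 stands at the limit of > 100000 nM in this assay, at which 1 of the 2 values shown sits, compound 3 is expected to remain a weak inhibitor in this assay, with no step in either direction beyond the scatter to point to. Compound 3 is expected to give about 80000 nM, within 20000 nM to 300000 nM.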

Compound 3, half-maximal inhibitory concentration: > 100000 nM
Compound 3 was reported as a limit (the forecaster's own chance of this, stated with the estimate: 60%); middle value at least 1.2-fold (0.09 log units) away from the limit.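

Within the data shown here, compound 1 and compound 3 are both reported only as limits in this assay, so no step between them can be read. The compounds shown leave open whether any chain on the shared core gives a measurable value in this assay.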